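Resolving the stereocentre: compound 3 to compound 4

The source may hold more compounds than are shown below. What is called first, only, known or untested is meant among the compounds shown, and "the series" means these compounds.

Of the compounds shown here, three of the shared core have been measured in an assay on isolated protein for inhibition of aldehyde dehydrogenase 1A1 (Homo sapiens); on this read-out lower numbers stand for stronger inhibition and higher numbers for weaker inhibition. Compound 1 `Cn1ncc2c(=O)n(-c3ccccc3)c(SC(C)(C)c3ccccc3)nc21` gives 1900 nM, compound 2 `CC(Sc1nc2c(cnn2C)c(=O)n1-c1ccccc1)c1ccccn1` gives 242 nM, and compound 3 `CC(Sc1nc2c(cnn2C)c(=O)n1-c1ccccc1)c1ccccc1` gives 130 nM. Compound 3 holds the lowest of the three numbers; the step of a 15-fold lower number from compound 1 to compound 3 (1.16 log units; beyond the scatter) is beyond the scatter, as is a 7.9-fold lower number from compound 1 to compound 2 (0.89 log units; beyond the scatter), whereas the step of a 1.9-fold lower number from compound 2 to compound 3 (0.27 log units; within the scatter) is within the scatter, so no order between compound 2 and compound 3 is claimed.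

Compound 4 `C[C@H](Sc1nc2c(cnn2C)c(=O)n1-c1ccccc1)c1ccccc1` differs from compound 3 only in this respect: the two compounds have the same atoms and bonds; at least one stereo element is drawn with a configuration in one of them and without one in the other: 1 of 1 stereo elements differ; a stereocentre at a saturated chain carbon is drawn without a configuration in compound 3 and S in compound 4. Compound 3 is thus a mixture at that centre and compound 4 a single configuration. Among the measured compounds shown here, no measured step concerns configuration; the steps of a 15-fold lower number from compound 1 to compound 3 (1.16 log units; beyond the scatter) and a 1.9-fold lower number from compound 2 to compound 3 (0.27 log units; within the scatter) touch the same chain carbon but alter its substituents, not its configuration. A single configuration of a mixture may give a number equal to, lower than or higher than the mixture; which applies here cannot be read from these compounds. Compound 4 is therefore expected in this assay at roughly 100 nM, an estimated step of a 1.3-fold lower number from compound 3 to compound 4 (0.11 log units; within the scatter), with a range from 40 nM to 400 nM.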

Compound 4, half-maximal inhibitory concentration: 1410 nM
The estimate for compound 4 lay 14-fold (1.15 log units) below the measured number; measured number outside the range, above it.
By their numbers in this assay, from the lowest: compounds 3 and 2 (each within the scatter of the next); then compounds 4 and 1 (each within the scatter of the next).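

In this assay the stereocentre at the saturated chain carbon matters in its own right, and the change of configuration alone accounts for an 11-fold higher number from compound 3 to compound 4 (1.04 log units; beyond the scatter) with no atom altered: the fact that one of compounds 3 and 4 is drawn with a defined configuration and the other without, at the place where they differ.

Compound 4 also stands apart from the unresolved pyridin-2-yl compound, as a 5.8-fold higher number from compound 2 to compound 4 (0.77 log units; beyond the scatter) is beyond the scatter, whereas a 1.3-fold lower number from compound 1 to compound 4 (0.13 log units; within the scatter) is within it, so the S form does not keep the advantage that the mixture held over compound 1. Among the compounds shown here, a mixture with a lower number than its S form points to the configuration not drawn in compound 4 as the one carrying the lower number.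

The compounds shown leave open what the R form gives alone and whether compound 2 divides in the same way. Also open, from the compounds shown here alone, is whether ethyl or hydroxymethyl in place of the methyl on that chain carbon would preserve the difference between configurations.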